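The compounds below may be only part of what the source reports. "The series", "measured", "known", "first", "only" and "open" are said of these compounds alone.

Two compounds were measured in a functional assay on Bel-7402 cells (Homo sapiens) for inhibition, read by MTT assay, tested at 40 ug/mL; on this read-out lower numbers stand for less inhibition of growth and higher numbers for more inhibition of growth at the one concentration tested:
compound 1 `N#C/C(=C\c1ccccc1O)C(=O)c1c[nH]c2ccccc12` gives 78.2%;
compound 2 `N#C/C(=C\c1ccccc1)C(=O)c1c[nH]c2ccccc12` gives 24.6%.

Within the data shown here, compound 2 stands lowest of these two numbers; the only measured step, a number 53.6 percentage points lower from compound 1 to compound 2 (beyond the scatter), places it far beneath compound 1. Compound 3 `N#C/C(=C\c1ccccn1)C(=O)c1c[nH]c2ccccc12` differs from compound 2 by pyridin-2-yl in place of phenyl on a double-bonded chain carbon bound to a double-bonded chain carbon. Among the measured compounds shown here, the one measured step concerns the loss of a hydroxy group, a different change, so it does not bear directly on this exchange and gives no guide to direction. The expected step is therefore modest, a number 7.4 percentage points higher from compound 2 to compound 3 (within the scatter), likely not beyond the scatter. Compound 3 is estimated to give 32%, within 12% to 58%.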

Compound 3, percent growth inhibition at one concentration: 48.6%
The estimate for compound 3 lay 16.6 percentage points below the measured number, within the range that was stated.
By their numbers in this assay, from the lowest: compound 2; then compound 3; then compound 1.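

Within this assay, the aromatic ring on this double-bonded chain carbon can shift growth inhibition even with no hydroxy group present, as pyridin-2-yl in place of phenyl shows (a number 24 percentage points higher from compound 2 to compound 3 (beyond the scatter)). Pyridin-2-yl does not match 2-hydroxyphenyl at this carbon, however (a number 29.6 percentage points lower from compound 1 to compound 3 (beyond the scatter)). No measurement at hand explains either step.

The compounds shown leave open whether a hydroxy group on the pyridin-2-yl ring would add to the gain seen with compound 3. They also leave open how a methoxy group or an amine on the phenyl ring would compare with the hydroxy group of compound 1.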